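The source may hold more compounds than are shown below. What is called first, only, known or untested is meant among the compounds shown, and "the series" means these compounds.

Working notes on the series.

Compound 1 `COc1cc(C(=O)c2sc3ccccc3c2-c2ccc(F)cc2)cc(OC)c1OC` gives the lowest number among the three compounds measured in a functional assay on A549 cells (Homo sapiens) for antiproliferative activity, read by MTT assay, with a stated time of 72 h (on this read-out lower numbers stand for stronger inhibition and higher numbers for weaker inhibition), at 3200 nM. Compound 2 `COc1ccc(-c2c(C(=O)c3cc(OC)c(OC)c(OC)c3)sc3ccccc23)cc1` gives 4400 nM in this assay, and the step of a 1.4-fold higher number from compound 1 to compound 2 (0.14 log units; within the scatter) lies within the scatter. Compound 3 `COc1ccc(Nc2c(C(=O)c3cc(OC)c(OC)c(OC)c3)sc3ccccc23)cc1` gives 9300 nM, so that a 2.9-fold higher number from compound 1 to compound 3 (0.46 log units; beyond the scatter) and a 2.1-fold higher number from compound 2 to compound 3 (0.33 log units; beyond the scatter) both register as modest weakenings.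

Compound 4 `CCOc1ccc(Nc2c(C(=O)c3cc(OC)c(OC)c(OC)c3)sc3ccccc23)cc1` has not yet been measured. Relative to compound 1 the change is (4-ethoxyphenyl)amino in place of 4-fluorophenyl on an aromatic carbon. The measured steps that bear on this are the two that introduce the (4-methoxyphenyl)amino group, a 2.9-fold higher number from compound 1 to compound 3 (0.46 log units; beyond the scatter) and a 2.1-fold higher number from compound 2 to compound 3 (0.33 log units; beyond the scatter); both go toward weaker inhibition by a modest margin. Within the data shown here, no measured pair separates an ethoxy group from a methoxy group on that aromatic ring, so that part of the change is uninformed. A modest rise in the number, comparable to the step to compound 3, is therefore expected: a 3.1-fold higher number from compound 1 to compound 4 (0.49 log units; beyond the scatter). The estimate for compound 4 in this assay is 10000 nM, with a range from 4000 nM to 25000 nM.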

Compound 4, half-maximal inhibitory concentration: 1400 nM
Beside the measured number, compound 4's estimate is 7.1-fold (0.85 log units) above it; measured number below the stated range.
By their numbers in this assay, from the lowest: compound 4; then compounds 1 and 2 (each within the scatter of the next); then compound 3.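

In this assay, among these compounds, the (4-ethoxyphenyl)amino group reverses the direction seen with the (4-methoxyphenyl)amino group: a 2.3-fold lower number from compound 1 to compound 4 (0.36 log units; beyond the scatter) and a 3.1-fold lower number from compound 2 to compound 4 (0.50 log units; beyond the scatter) both go toward stronger inhibition, although the earlier steps to compound 3 went toward weaker inhibition. The single added methyl gives the largest step in the series, with a 6.6-fold lower number from compound 3 to compound 4 (0.82 log units; beyond the scatter) as its size, so the amino link at this position does not by itself fix the outcome. No evidence on hand explains this reversal.

As far as these compounds go, it remains open whether a longer chain, such as propoxy or butoxy, would lower the number further or whether the gain is specific to ethoxy. From the compounds shown here alone, it is also open whether a 4-ethoxyphenyl group in place of (4-ethoxyphenyl)amino would give a similar number.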